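The source may hold more compounds than are shown below. What is called first, only, known or untested is meant among the compounds shown, and "the series" means these compounds.

Of the compounds shown here, three have been measured in a physicochemical assay for lipophilicity, read by HPLC, in phosphate buffer, measured as chromatographic lipophilicity, at pH 7.4; on this read-out higher numbers stand for higher lipophilicity and lower numbers for lower lipophilicity. Compound 1 `CCOc1ccc2nc(C(F)(F)F)cc(OCC(=O)Nc3cc(C)cc(C)c3)c2c1` gives 7.55, and compound 2 `COc1ccc2nc(C)cc(OC(C)C(=O)Nc3cc(C)cc(C)c3)c2c1` gives 5.76. Compound 3 `COc1cccc(NC(=O)COc2cc(C)nc3ccc(OC)cc23)c1` gives 4.49, the lowest of the three numbers: compound 2 lies nearest to it, with a value higher by a margin beyond the usual scatter, and compound 1 lies furthest, higher by a wider margin that is also beyond the scatter.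

The next compound is compound 4 `COc1ccc2nc(C)cc(OCC(=O)NC3CONC3=O)c2c1`. Compared with compound 3, the difference is a group of 6 heavy atoms (3 carbon, 1 nitrogen, 2 oxygen; one five-membered non-aromatic ring with 2 hetero atoms) in place of a group of 8 heavy atoms (7 carbon, 1 oxygen; one six-membered aromatic ring of carbon only), on an amide-type nitrogen. The group that leaves, 3-methoxyphenyl, is a six-membered aromatic ring of carbon only; what enters in its place is a smaller group built around a five-membered non-aromatic ring with two hetero atoms, carrying a hydrogen-bond donor and two acceptors.

Within the data shown here, no measured pair shows a change of this kind, so the expectation rests on the structures alone. In this assay the step of a number 2.69 log units lower from compound 3 to compound 4 (beyond the scatter) is expected to be large and downward, well beyond the scatter. For compound 4 the estimated value is 1.8, with a range from 0.8 to 2.8.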

Compound 4, distribution coefficient: 0.79
The estimate for compound 4 lay 1.01 log units above the measured number, outside the stated range (below it).
By their numbers in this assay, from the lowest: compound 4; then compound 3; then compound 2; then compound 1.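

In this assay, a change at this one place is enough to move the number a long way: on the amide-type nitrogen, replacing 3-methoxyphenyl with the five-membered non-aromatic ring with 2 hetero atoms gives a number 3.70 log units lower from compound 3 to compound 4 (beyond the scatter). Among these compounds, this is the first step here between compounds that differ in only one place, so it measures the effect of this exchange with the rest of the structure held fixed. No measured information bears on which feature of the exchange produced this step.

The exchange alters ring size, aromatic character and hetero atoms together, and a single pair cannot separate them. A cyclopentyl group or an unsubstituted phenyl group on the same nitrogen would help show how much of the step goes with each feature.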